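Furanylmethylamino-quinazoline piperazines: aryl swap on the ring nitrogen

The source may report more compounds than this note shows. Statements on the series, on what has been measured and on what is new or still open speak of the compounds shown alone.

Three members of the series have numbers in a functional assay on DU-145 cells (Homo sapiens) for cytotoxicity, read by MTT assay, with a stated time of 2 days; on this read-out higher numbers stand for weaker inhibition and lower numbers for stronger inhibition. Compound 1 `Cc1cccc(N2CCN(CCCNc3nc(NCc4ccco4)c4ccccc4n3)CC2)c1C` gives 930 nM. Compound 2 `Clc1cccc(N2CCN(CCCNc3nc(NCc4ccco4)c4ccccc4n3)CC2)c1Cl` gives 3710 nM, and compound 3 `Clc1cccc(N2CCN(CCCCNc3nc(NCc4ccco4)c4ccccc4n3)CC2)c1Cl` gives 3870 nM. Compound 1 and compound 2 share a core and differ at one place, (2,3-dimethylphenyl in place of 2,3-dichlorophenyl on an amine nitrogen in a ring), which gives the step of a 4.0-fold lower number from compound 2 to compound 1 (0.60 log units; beyond the scatter). Compound 2 and compound 3 have different cores, and that difference is not broken down here; their two values lie within the scatter of each other.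

Compound 4 `Cc1cccc(N2CCN(CCCCNc3nc(NCc4ccco4)c4ccccc4n3)CC2)c1C` is not yet measured. It relates to compound 3 as compound 1 relates to compound 2: 2,3-dimethylphenyl in place of 2,3-dichlorophenyl on an amine nitrogen in a ring, the same change at the same place, on the core of compound 3. In this assay compound 4 is expected to show a step of a 3.9-fold lower number from compound 3 to compound 4 (0.59 log units; beyond the scatter), resting on the single earlier occurrence of this change, a 4.0-fold lower number from compound 2 to compound 1 (0.60 log units; beyond the scatter), and on the closeness of the values of compound 2 and compound 3. On that basis compound 4 is estimated at 1000 nM, with an expected range from 400 nM to 2500 nM.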

Compound 4, half-maximal inhibitory concentration: 1070 nM
Beside the measured number, compound 4's estimate is 1.1-fold (0.03 log units) below it, and the stated range covers the measured number.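

In this assay the swap of 2,3-dichlorophenyl for 2,3-dimethylphenyl on an amine nitrogen in a ring carries over to the core of compound 3, giving a 3.6-fold lower number from compound 3 to compound 4 (0.56 log units; beyond the scatter). The step on this core matches the step on the core of compound 1, so within this small set the change behaves as transferable: the same change on two cores in this assay, a 4.0-fold lower number (0.60 log units; beyond the scatter) from compound 2 to compound 1 and a 3.6-fold lower number (0.56 log units; beyond the scatter) from compound 3 to compound 4, 1.1-fold (0.04 log units) apart, within the scatter of two such steps. Two cores are a narrow base, however: the agreement does not show that the step would hold on any other core in the series, and it gives no explanation of why the 2,3-dimethylphenyl compounds carry the lower numbers.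

Still open, from the compounds shown here alone, is whether other groups on that ring nitrogen, such as an unsubstituted phenyl, a methoxyphenyl or a pyridyl ring, would extend the same trend or break it. Going by these compounds, it is also open whether the step survives on a longer chain than that of compound 4, or with a benzylamine in place of the furanylmethylamine.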